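Replacing the benzyl amide group in the shared core

The compounds below may be only part of what the source reports. "The series", "measured", "known", "first", "only" and "open" are said of these compounds alone.

Compound 1, `C=CC1=C(C(=O)NCc2ccccc2)C(c2ccc(OC)c(OC)c2)OC1`, reaches only the limit of a functional assay on SW480 cells (Homo sapiens) for cytotoxicity, read by MTT assay, with a stated time of 24 h (on this read-out higher numbers stand for weaker inhibition and lower numbers for stronger inhibition), with > 100000 nM.
Compound 2, `C=CC1=C(C(=O)NCc2ccccc2)C(c2ccc(OC)cc2)OC1`, gives 39500 nM in this assay.

Compound 2 thus holds the only number shown; the other value is a limit. The step of an at least 2.5-fold lower number from compound 1 to compound 2 (0.40 log units; beyond the scatter) rests on (the limit of > 100000 nM in this assay, at which 1 of the 2 values shown sits), so its true size is not pinned down.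

Compound 3, `C=CC1=C(C(=O)Nc2ccc(OCC)cc2)C(c2ccc(OC)cc2)OC1`, differs from compound 2 at the amide only: 4-ethoxyphenyl in place of benzyl on an amide-type nitrogen. No measured step touches the amide side of the shared core, since the single step shown changes a methoxy on an aromatic carbon of the other side. There is therefore nothing to argue for a shift beyond the scatter in either direction, and the expectation for compound 3 is a value close to that of compound 2, with wide uncertainty. Compound 3 is estimated at 40000 nM, with a range from 10000 nM to 150000 nM. This estimate means an expected step of a 1.0-fold higher number from compound 2 to compound 3 (0.01 log units; within the scatter).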

Compound 3, half-maximal inhibitory concentration: > 100000 nM
Compound 3 was reported as a limit (the forecaster's own chance of this, stated with the estimate: 30%); middle value at least 2.5-fold (0.39 log units) away from the limit.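

Within the data shown here, the amide side of the shared core, which no earlier step touched, turns out to matter in this assay: putting 4-ethoxyphenyl in place of benzyl on the amide-type nitrogen gives an at least 2.5-fold higher number from compound 2 to compound 3 (0.40 log units; beyond the scatter). As far as these compounds go, compound 3 is reported only as a limit, so this step gives a smallest size and the true size stays open: (the limit of > 100000 nM in this assay, at which 2 of the 3 values shown sit). Compound 2 now has a measured number while the two compounds that each differ from it in one place, compound 1 on the methoxy side and compound 3 on the amide side, both stop at this limit, so changes on either side of the shared core can move the result beyond the scatter.

The step swaps the whole benzyl for the whole 4-ethoxyphenyl, so the compounds shown cannot separate the part played by the ethoxy group from that of the rest of the change, which a plain phenyl on the same nitrogen would help to do. From the compounds shown here alone, it also stays open whether any group on this nitrogen, such as a longer chain ending in an amine or a carboxylic acid, would give a lower number than benzyl does.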